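Swapping Propargyl for Cyclopropyl on the Amide Nitrogen

The compounds below may be only part of what the source reports. "The series", "measured", "known", "first", "only" and "open" are said of these compounds alone.

Of the compounds shown here, three sharing one core have been tested in a toxicity assay on the whole organism (strain Icem-CET (SPF Caw)) for cytotoxicity, with Mus musculus as the target; on this read-out lower numbers stand for an effect already at smaller amounts and higher numbers for an effect only at larger amounts of compound. Compound 2 `C#CCNC(=O)/C(C)=C(\C)c1ccc(C)cc1` gives 150 mg/kg, the highest of the three numbers, though both other compounds sit within the scatter of it. Compound 1 `C/C(C(=O)NC1CC1)=C(/C)c1ccc(Br)cc1` gives 130 mg/kg in this assay, and compound 3 `C#CCNC(=O)/C(C)=C(\C)c1ccc(F)cc1` gives 100 mg/kg. Going by the values given here, the one single-site step among them, a 1.5-fold lower number from compound 2 to compound 3 (0.18 log units; within the scatter), lies within the scatter.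

Compound 4 `C/C(C(=O)NC1CC1)=C(/C)c1ccc(C)cc1` differs from compound 2 in one place: cyclopropyl in place of propargyl on an amide-type nitrogen. Among the compounds with values here, no measured pair isolates this change. Within the data shown here, compound 1 also carries a cyclopropyl on its amide nitrogen, but with a different aromatic substituent, so its value shows only that such a compound lands near the others. The measured step bears on the question indirectly at most. With all three numbers so close, no step beyond the scatter is expected in this assay, and the expected step of a 1.1-fold lower number from compound 2 to compound 4 (0.03 log units; within the scatter) is small. Compound 4 is therefore estimated at 140 mg/kg, with a range from 80 mg/kg to 250 mg/kg.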

Compound 4, dose for half-maximal effect: 150 mg/kg
For compound 4 the middle estimate is 1.1-fold (0.03 log units) below the measured one, within the range that was stated.
By their numbers in this assay, from the lowest: compounds 3, 1, 2 and 4 (each within the scatter of the next).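

Cyclopropyl in place of propargyl on the amide-type nitrogen can now be read directly in this assay, and the pair shows no change at the digits printed from compound 2 to compound 4 (within the scatter). On this read-out, then, the open chain with its triple bond and the three-membered ring, each with 3 heavy atoms, cannot be told apart at this position. The second pair, with cyclopropyl held constant, gives a 1.2-fold higher number from compound 1 to compound 4 (0.06 log units; within the scatter) for methyl in place of bromo on an aromatic carbon, and no available measurement offers an explanation for either result.

As far as these compounds go, what remains open is whether a group of another kind on this nitrogen, such as a longer alkyl chain or a chain ending in a carboxylic acid, would give a step beyond the scatter. The same question stands for an amine on the aromatic ring.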